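Replacing 2-hydroxyphenyl with 4-nitrophenyl on a shared core

The source may hold more compounds than are shown below. What is called first, only, known or untested is meant among the compounds shown, and "the series" means these compounds.

Measured in a functional assay on RAW264.7 cells (Mus musculus) for inhibition, read by Griess assay, with stated times of 3 h and 24 h; a lower number here means a stronger inhibitor, a higher number a weaker inhibitor:
- Compound 1 `C=C1CCC2[C@](C)(CO)[C@H](O)CC[C@@]2(C)[C@@H]1CCn1cncn1`: > 100000 nM, a limit and not a number
- Compound 2 `C=C1CCC2[C@](C)(CO)[C@H](O)CC[C@@]2(C)[C@@H]1CCOc1ccccc1O`: 47700 nM

For the measured compounds named here, compound 2 holds the only true number so far. The other result is the limit of > 100000 nM in this assay, at which 1 of the 2 values shown sits.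

Compound 3 `C=C1CCC2[C@](C)(CO)[C@H](O)CC[C@@]2(C)[C@@H]1CCOc1ccc([N+](=O)[O-])cc1` has 4-nitrophenyl in place of 2-hydroxyphenyl on an oxygen on a saturated carbon. Going by the values given here, the sole measured step, an at least 2.0-fold lower number from compound 1 to compound 2 (0.32 log units; beyond the scatter), exchanged a different group, so it gives little guidance, and no shift beyond the scatter is expected in this assay. The expected step is a 1.1-fold lower number from compound 2 to compound 3 (0.03 log units; within the scatter). For compound 3 the estimated value is 45000 nM, with an expected range from 15000 nM to 100000 nM.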

Compound 3, half-maximal inhibitory concentration: 3380 nM
For compound 3 the middle estimate is 13-fold (1.12 log units) above the measured one, outside the stated range (below it).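

In this assay the group on an oxygen on a saturated carbon clearly matters: 4-nitrophenyl in place of 2-hydroxyphenyl gives a 14-fold lower number from compound 2 to compound 3 (1.15 log units; beyond the scatter), with the rest of the molecule unchanged. The earlier step exchanged a whole group, whereas this one shows that two groups built on the same six-membered aromatic ring are far from interchangeable here. Nothing shown explains the size of this step.

As far as these compounds go, the change removes a hydroxyl and adds a nitro group together, so their separate contributions remain unknown. From the compounds shown here alone, whether a plain phenyl or a phenyl carrying an amine would keep this gain also remains open.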